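Side-chain oxygen in the bis-aryl series

The compounds below may be only part of what the source reports. "The series", "measured", "known", "first", "only" and "open" are said of these compounds alone.

Values in a functional assay on HeLa cells (Homo sapiens) for cytotoxicity, read by WST assay, with a stated time of 48 h; a higher number here means a weaker inhibitor, a lower number a stronger inhibitor:
- compound 1 `COC[C@H](C)[C@H](C)C(c1ccc(O)c(OC)c1)c1ccc(O)c(OC)c1` gives 72000 nM
- compound 2 `COC[C@H](C)[C@@H](C)C(c1ccc(O)c(OC)c1)c1ccc(O)c(OC)c1` gives 77000 nM
- compound 3 `CC[C@H](C(C)C)C(c1ccc(O)c(OC)c1)c1ccc(O)c(OC)c1` gives 9700 nM

Compound 3 has the lowest number of the three in this assay, so it is the strongest inhibitor measured so far. Compound 4 `COc1cc(C(c2ccc(O)c(OC)c2)[C@H](CO)C(C)C)ccc1O` differs from it by hydroxy in place of methyl on a saturated chain carbon, three bonds along the chain from two aromatic carbons, which means hydroxy in place of methyl on a saturated chain carbon, three bonds along the chain from two aromatic carbons. Ethyl thus becomes hydroxymethyl.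

Within the data shown here, no measured step makes this exact change. Among the measured compounds shown here, the nearest guide is that compounds 1 and 2 are the only measured members with oxygen in the chain, and the steps to compound 3 are sizeable: a 7.4-fold lower number from compound 1 to compound 3 (0.87 log units; beyond the scatter) and a 7.9-fold lower number from compound 2 to compound 3 (0.90 log units; beyond the scatter). Configuration gives no separate guide, as a 1.1-fold higher number from compound 1 to compound 2 (0.03 log units; within the scatter). Those chains also differ in other ways, so the analogy is only partial. A higher number is therefore expected, with the estimated change being a 3.1-fold higher number from compound 3 to compound 4 (0.49 log units; beyond the scatter). For compound 4 the expected value is 30000 nM, with an estimated range of 10000 nM to 90000 nM.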

Compound 4, half-maximal inhibitory concentration: > 100000 nM
Compound 4: only a limit was reported; the forecaster's own chance of this, stated with the estimate: 10%; middle value at least 3.3-fold (0.52 log units) from the limit.
By their numbers in this assay, from the lowest: compound 3; then compounds 1 and 2 (each within the scatter of the next). At a limit, above all of these: compound 4.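

In this assay compound 4 gives > 100000 nM, which is a limit of the assay and not a number: the limit of > 100000 nM in this assay, at which 1 of the 4 values shown sits. Hydroxy in place of methyl on a saturated chain carbon, three bonds along the chain from two aromatic carbons, gives an at least 10-fold higher number from compound 3 to compound 4 (1.01 log units; beyond the scatter), so this one change, ethyl to hydroxymethyl, is enough to produce a large step at this place. The floors of an at least 1.2-fold higher number from compound 2 to compound 4 (0.11 log units; that floor lies within the scatter) and an at least 1.3-fold higher number from compound 1 to compound 4 (0.14 log units; that floor lies within the scatter) fix no order among the three chains that carry oxygen.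

Where compound 4 truly lies remains open, and so does the full size of its step. Also open, on these data alone, is whether an aminomethyl group or a longer chain such as propyl at this place would behave like ethyl or like hydroxymethyl.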